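A few compounds are considered here, and "the series" means these few. Any claim that something is new, unique, unknown or untested is made for them only; others in the source may bear on it.

In a functional assay on A20 cells (Mus musculus) for inhibition, with stated times of 1 h, 16 h and 24 h (on this read-out lower numbers stand for stronger inhibition and higher numbers for weaker inhibition), compound 1 `N#CCNC(=O)[C@@H]1C[C@@H](S(=O)(=O)CC2CC2)C[C@H]1C(=O)N1CCOCC1` gives 4510 nM and compound 2 `CC(C)(C#N)NC(=O)[C@@H]1C[C@@H](S(=O)(=O)c2ccccc2)C[C@H]1C(=O)N1CCOCC1` gives 43 nM while compound 3 `N#CC1(NC(=O)[C@@H]2C[C@@H](S(=O)(=O)c3ccccc3)C[C@H]2C(=O)N2CC3CCC(C2)O3)CC1` gives 16 nM as the lowest number of the three. The other two compounds both sit above compound 3 by more than the usual scatter, so compound 3 is the most potent of those measured so far.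

Compound 4 `N#CC1(NC(=O)[C@@H]2C[C@@H](S(=O)(=O)c3ccccc3)C[C@H]2C(=O)N2CCS(=O)(=O)CC2)CC1` differs from compound 3 in one place, on a carbonyl carbon, where the change is a group of 8 heavy atoms (4 carbon, 1 nitrogen, 2 oxygen, 1 sulfur; one six-membered non-aromatic ring with 2 hetero atoms) in place of a group of 8 heavy atoms (6 carbon, 1 nitrogen, 1 oxygen; one five-membered non-aromatic ring with 1 hetero atom, one six-membered non-aromatic ring with 2 hetero atoms), on a carbonyl carbon and the entering group is 1,1-dioxothiomorpholin-4-yl. Among the measured compounds shown here, no two measured compounds differ in only one place, so the data do not directly show what such a swap does. Compound 2 carries another group on this carbonyl carbon and still gives 43 nM in this assay so a large loss is not expected. A modest rise in the number is expected, near the scatter or somewhat beyond it. The estimated change is a 2.2-fold higher number from compound 3 to compound 4 (0.34 log units; beyond the scatter) and it remains only an expectation. In this assay compound 4 is expected at 35 nM (estimated range 11 nM to 110 nM).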

Compound 4, half-maximal inhibitory concentration: 816 nM
The estimate for compound 4 lay 23-fold (1.37 log units) below the measured number, and the stated range ends below it.
By their numbers in this assay, from the lowest: compound 3; then compound 2; then compound 4; then compound 1.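

In this assay, among the compounds shown here, the only comparison here that changes one place alone is the swap on the carbonyl carbon, which gives a 51-fold higher number from compound 3 to compound 4 (1.71 log units; beyond the scatter). This shows that the position is far from indifferent to the group it carries. The two groups have the same heavy-atom count, so that count alone does not settle the outcome here. No measurement shown here explains why the 1,1-dioxothiomorpholin-4-yl group gives so much weaker inhibition. On these data alone, whether a piperidine ring or a dimethylamino group on this carbonyl carbon would land nearer compound 3 or nearer compound 4 remains open. As far as these compounds go, it is also open whether this swap would produce a step of similar size with a different group on the sulfonyl or on the nitrile-bearing amide.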